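The compounds below may be only part of what the source reports. "The series", "measured", "known", "first", "only" and "open" are said of these compounds alone.

Of the compounds shown here, three sharing one core have been measured in a functional assay on NCI-H522 cells (Homo sapiens) for inhibition, read by sulforhodamine B assay, with a stated time of 48 h; on this read-out lower numbers stand for stronger inhibition of growth and higher numbers for weaker inhibition of growth. Compound 1 `COc1cc(-c2nn(-c3cccc(NC(=O)Nc4cc(C(F)(F)F)cc(C(F)(F)F)c4)c3)cc2-c2ccncc2)ccc1Cl` gives 623 nM. Compound 2 `COc1cc(-c2nn(-c3cccc(NC(=O)Nc4ccc(Cl)c(Cl)c4)c3)cc2-c2ccncc2)ccc1Cl` gives 811 nM. Compound 3 `O=C(Nc1cccc(-n2cc(-c3ccncc3)c(-c3ccc(Cl)c(O)c3)n2)c1)Nc1ccc(Cl)c(Cl)c1` gives 1190 nM. Compound 2 holds the middle number of the three, yet its gap to compound 1 and its gap to compound 3 each fall within the scatter, so the three numbers cannot be told apart. Within the data shown here, the only step between compounds differing in a single place is a 1.5-fold higher number from compound 2 to compound 3 (0.17 log units; within the scatter), which changes nothing beyond the scatter. Compound 4 `COc1cc(-c2nn(-c3cccc(NC(=O)c4ccc(Cl)c(C(F)(F)F)c4)c3)cc2-c2ccncc2)ccc1Cl` differs from compound 2 by 4-chloro-3-(trifluoromethyl)phenyl in place of (3,4-dichlorophenyl)amino on a carbonyl carbon, so a urea becomes an amide. Among the measured compounds shown here, no measured step touches this part of the molecule, and the comparison of compound 1 with compound 2 alters a different group, so nothing measured bears on the change directly. The expectation for compound 4 therefore rests only on the narrow spread seen so far, and a step of a 1.5-fold higher number from compound 2 to compound 4 (0.17 log units; within the scatter) is expected, with a wide range. Compound 4 is estimated at 1200 nM, between 400 nM and 4000 nM.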

Compound 4, concentration for 50% growth inhibition: 1040 nM
For compound 4 the middle estimate is 1.2-fold (0.06 log units) above the measured one; measured number inside the range.
By their numbers in this assay, from the lowest: compounds 1, 2, 4 and 3 (each within the scatter of the next).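

In this assay, putting 4-chloro-3-(trifluoromethyl)phenyl in place of (3,4-dichlorophenyl)amino on the carbonyl carbon gives a 1.3-fold higher number from compound 2 to compound 4 (0.11 log units; within the scatter), so the two compounds cannot be told apart. Among these compounds, this is the first measured change at this position, and it shows that a urea can become an amide here, with the group that leaves carrying 1 hydrogen-bond donor and the group that enters carrying 0 hydrogen-bond donors, without a change beyond the scatter. Nothing measured on these groups accounts for this result.

Going by these compounds, the linking atoms and the ring substituents change together in this one step, so their separate contributions remain unknown. Also open, on these data alone, is what a carboxylic acid or an amine on that ring, or a longer alkyl chain in place of the ring, would do to growth inhibition.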